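Halogen pattern on the phenyl of a shared core

A few compounds are considered here, and "the series" means these few. Any claim that something is new, unique, unknown or untested is made for them only; others in the source may bear on it.

Measured so far:
compound 1, `Cn1ccc2c(Oc3ccc(NC(=O)c4nn(-c5ccc(Cl)cc5)ccc4=O)cc3)ccnc21`, > 60000 nM
compound 2, `Cn1ccc2c(Oc3ccc(NC(=O)c4nn(-c5ccc(Br)cc5F)ccc4=O)cc3)ccnc21`, 35700 nM

In a functional assay on A549 cells (Homo sapiens) for cytotoxicity, read by MTT assay, with a stated time of 72 h (on this read-out lower numbers stand for stronger inhibition and higher numbers for weaker inhibition), compound 1 gives only a limit, > 60000 nM. Compound 2 gives 35700 nM in this assay, the single number shown in the set. Among the compounds with values here, the one measured step, an at least 1.6-fold lower number from compound 1 to compound 2 (0.22 log units; that floor lies within the scatter), cannot be sized better because of the limit of > 60000 nM in this assay, at which 1 of the 2 values shown sits.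

Compound 3 is `Cn1ccc2c(Oc3ccc(NC(=O)c4nn(-c5ccc(Cl)c(F)c5)ccc4=O)cc3)ccnc21`. It differs from compound 2 by 4-chloro-3-fluorophenyl in place of 4-bromo-2-fluorophenyl on an aromatic nitrogen. Within the data shown here, only the step from compound 1 to compound 2 bears on this change, and it swaps halogen pattern on the same phenyl; its floor lies within the scatter, so it gives no direction to carry over. For compound 3 no step beyond the scatter is therefore expected in this assay, with a real chance that the read-out again stops at a limit rather than a number.

Compound 3 is estimated at 45000 nM, within 18000 nM to 90000 nM. The expected step is a 1.3-fold higher number from compound 2 to compound 3 (0.10 log units; within the scatter).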

Compound 3, half-maximal inhibitory concentration: > 60000 nM
Compound 3 ended at the assay's limit; the forecaster's own chance of this, stated with the estimate: 40%; middle value at least 1.3-fold (0.12 log units) away from the limit.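

In this assay compound 3 gives > 60000 nM, which is a limit of the assay and not a number. Within the data shown here, the change to 4-chloro-3-fluorophenyl on the aromatic nitrogen gives an at least 1.6-fold higher number from compound 2 to compound 3 (0.22 log units; that floor lies within the scatter), so this second change of halogen pattern at the position also yields no step known to lie beyond the scatter, and it alters both the heavier halogen and the place of the fluoro, leaving neither one separable from the other. The step from compound 1 to compound 3, fluoro in place of hydrogen on an aromatic carbon, cannot be read, and the comparisons in this small set stay bounded by one feature of the data: the limit of > 60000 nM in this assay, at which 2 of the 3 values shown sit.

Among the compounds shown, the effect of bromo alone cannot be told apart from that of fluoro, as no pair differs only in that one halogen. Also open, going by these compounds, is how the read-out in this assay would respond to a phenyl carrying an amine or a carboxylic acid in place of the halogens, and whether any such group would give a number clearly apart from the limit.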